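The source may report more compounds than this note shows. Statements on the series, on what has been measured and on what is new or still open speak of the compounds shown alone.

Measured compounds:
Compound 1, `COc1cccc(Nc2nc(Oc3cccc(NC(=O)C=C(C)C)c3)c3sccc3n2)c1`: 25800 nM
Compound 2, `CC/C=C/C(=O)Nc1cccc(Oc2nc(Nc3cccc(OC)c3)nc3ccsc23)c1`: 29200 nM
Compound 3, `CC(C)=CC(=O)Nc1cccc(Oc2nc(Nc3cccc(C#N)c3)nc3ccsc23)c1`: 28300 nM

In a functional assay on A-431 cells (Homo sapiens) for inhibition, read by MTT assay, with a stated time of 72 h (on this read-out lower numbers stand for stronger inhibition and higher numbers for weaker inhibition), compound 1 gives 25800 nM, compound 2 gives 29200 nM and compound 3 gives 28300 nM; all three lie within the scatter of one another, so no order among them can be read. Compound 1 and compound 2 differ by but-1-en-1-yl in place of 2-methylprop-1-en-1-yl on a carbonyl carbon, and that change gave a 1.1-fold higher number from compound 1 to compound 2 (0.05 log units; within the scatter). Compound 1 and compound 3 differ by cyano in place of methoxy on an aromatic carbon, with a 1.1-fold higher number from compound 1 to compound 3 (0.04 log units; within the scatter).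

Compound 4, `CC/C=C/C(=O)Nc1cccc(Oc2nc(Nc3cccc(C#N)c3)nc3ccsc23)c1`, has not yet been measured in this assay. It stands to compound 3 as compound 2 stands to compound 1: the difference is but-1-en-1-yl in place of 2-methylprop-1-en-1-yl on a carbonyl carbon, and the place of the change is the same word for word in both pairs, so it is the same change. Because a 1.1-fold higher number from compound 1 to compound 2 (0.05 log units; within the scatter) was small, the step from compound 3 to compound 4 is expected to be a 1.1-fold higher number from compound 3 to compound 4 (0.05 log units; within the scatter). For compound 4 the value in this assay is therefore estimated at 32000 nM, expected between 15000 nM and 65000 nM.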

Compound 4, half-maximal inhibitory concentration: 36200 nM
Estimate against measurement, compound 4: 1.1-fold (0.05 log units) below, and the stated range covers the measured number.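

In this assay, but-1-en-1-yl in place of 2-methylprop-1-en-1-yl on a carbonyl carbon gave a 1.3-fold higher number from compound 3 to compound 4 (0.11 log units; within the scatter), and the change carried from one core to the other with no difference that can be read: the same change on two cores in this assay, a 1.1-fold higher number (0.05 log units; within the scatter) from compound 1 to compound 2 and a 1.3-fold higher number (0.11 log units; within the scatter) from compound 3 to compound 4, 1.1-fold (0.05 log units) apart, within the scatter of two such steps. Cyano in place of methoxy on an aromatic carbon gave a 1.2-fold higher number from compound 2 to compound 4 (0.09 log units; within the scatter), and this change also read alike in both settings: the same change on two cores in this assay, a 1.1-fold higher number (0.04 log units; within the scatter) from compound 1 to compound 3 and a 1.2-fold higher number (0.09 log units; within the scatter) from compound 2 to compound 4, 1.1-fold (0.05 log units) apart, within the scatter of two such steps. Every step lies within the scatter, so the four compounds show that neither change moved the number measurably in either setting, but they do not show that either change has a real effect of its own, or that the agreement would hold on other cores.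

Still open, on these data alone, is whether a longer chain or an amine-bearing chain on the carbonyl carbon would shift the number beyond the scatter. Also open, as far as these compounds go, is whether a carboxylic acid or a halogen in place of cyano or methoxy on the aromatic carbon would do so.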